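The compounds below may be only part of what the source reports. "The series", "measured", "known", "first", "only" and "open" are said of these compounds alone.

Measured so far in a functional assay on the whole organism (strain Sprague-Dawley) for inhibition, with Rattus norvegicus as the target; a higher number here means that more compound is needed for the effect, a lower number that less compound is needed:

Compound 1 `O=c1c(-c2nn[nH]n2)c[nH]c2c(F)ccc(F)c12` gives > 0.156 mg/kg, which is a limit of the assay and not a number.
Compound 2 `O=c1c(-c2nn[nH]n2)c[nH]c2c(F)cccc12` gives 0.625 mg/kg.

In this assay compound 2 stands on the only number shown, while the one further value is a limit (the limit of > 0.156 mg/kg in this assay, at which 1 of the 2 values shown sits). The step from compound 1 to compound 2 is a step that the limit leaves unreadable from compound 1 to compound 2, hydrogen in place of fluoro on an aromatic carbon, so its size cannot be read from the data.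

Compound 3 `CSc1cccc2c(=O)c(-c3nn[nH]n3)c[nH]c12` differs from compound 2 by methylsulfanyl in place of fluoro on an aromatic carbon. For the measured compounds named here, no measured step shows what methylsulfanyl in place of fluoro does here, and the single step available is unreadable, so no shift beyond the scatter is expected in either direction. Compound 3 is therefore estimated to give about 0.6 mg/kg in this assay, within a range of 0.15 mg/kg to 2.5 mg/kg. The estimated step of a 1.0-fold lower number from compound 2 to compound 3 (0.02 log units; within the scatter) is taken as none beyond the scatter.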

Compound 3, minimum effective dose: 10 mg/kg
Compound 3: the middle estimate sits 17-fold (1.22 log units) below what was measured; measured number outside the range, above it.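

In this assay, for the compounds shown here, methylsulfanyl in place of fluoro on this aromatic carbon gives a 16-fold higher number from compound 2 to compound 3 (1.20 log units; beyond the scatter), the first step whose size can be read. It shows that this carbon is not indifferent to what it carries: the shared core needs more compound with methylsulfanyl here than with fluoro, although only two heavy atoms enter for the one that leaves. Nothing shown here accounts for the size of this step.

Going by these compounds, compound 1 gives > 0.156 mg/kg, which is a limit and not a number, so its step cannot be read and what its second fluoro contributes stays open. On these data alone, it also remains open whether the loss follows from methylsulfanyl alone or would also appear with a chlorine, a methoxy group or an amine on this carbon.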